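A few compounds are considered here, and "the series" means these few. Any claim that something is new, unique, unknown or untested is made for them only; others in the source may bear on it.

Measured compounds:
compound 1, `COc1ccccc1/C=C/C(=O)c1ccc(OCC(=O)N[C@H]2CCOC2=O)cc1` — 7240 nM
compound 2, `O=C(CNc1ccc(Cl)cc1Cl)N[C@H]1CCOC1=O` — > 64000 nM
compound 3, `O=C(CNc1ccccc1Cl)N[C@H]1CCOC1=O` — > 64000 nM

All three compounds were tested in a functional assay on PC-3 cells (Homo sapiens) for antiproliferative activity, read by MTT assay, with a stated time of 72 h; a higher number here means a weaker inhibitor, a lower number a stronger inhibitor. Compound 1 is the only one of the three that yields a number: in this assay compound 1 gives 7240 nM. Compound 2 stops at a limit of the assay, > 64000 nM. Compound 3 likewise stops at a limit, > 64000 nM. Among the compounds with values here, the single measured step, a step that the two limits leave unreadable from compound 2 to compound 3, cannot be read because both of its ends sit at the limit of > 64000 nM in this assay, at which 2 of the 3 values shown sit.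

Compound 4, `O=C(COc1ccc(C(=O)/C=C/c2cccc(Cl)c2)cc1)N[C@H]1CCOC1=O`, differs from compound 1 by 3-chlorophenyl in place of 2-methoxyphenyl on a double-bonded chain carbon bound to a double-bonded chain carbon. Compound 2 and compound 3 carry the same lactone amide as the shared core but lack the chain of compound 1 on which this exchange takes place, so their unreadable step says nothing about it. Within the data shown here, no measured step bears on the change from compound 1 to compound 4, and the expectation therefore rests on the value of compound 1 alone.

With no guide from the data, the expected step is a 1.2-fold lower number from compound 1 to compound 4 (0.08 log units; within the scatter), a change that stays within the usual scatter. Compound 4 is accordingly estimated at 6000 nM, with a range from 2000 nM to 20000 nM.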

Compound 4, half-maximal inhibitory concentration: 4990 nM
Estimate against measurement, compound 4: 1.2-fold (0.08 log units) above; the measured number falls inside the stated range.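

In this assay, putting 3-chlorophenyl in place of 2-methoxyphenyl on a double-bonded chain carbon bound to a double-bonded chain carbon gives a 1.5-fold lower number from compound 1 to compound 4 (0.16 log units; within the scatter), so this exchange does not separate the two compounds. Within the data shown here, this is the first step that can be read, and it shows that this place on the chain accepts a swap of one substituted phenyl ring for another without a measurable difference, even though the hydrogen-bond acceptor of the leaving group has no counterpart in the entering group. Nothing measured here explains this result, and the limit values of the other compounds do not bear on the exchange.

This single pair changes both the substituent and its place on the ring, so the two changes cannot be told apart, and 3-methoxyphenyl would be the group needed to separate them. As far as these compounds go, it also remains open whether this place would still show no difference with a ring of a different kind, such as a phenyl ring carrying a carboxylic acid or an amine.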